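The compounds below may be only part of what the source reports. "The series", "measured", "known", "first", "only" and "open" are said of these compounds alone.

Measured so far:
- compound 1 `CCN(CC)CCCCN/C(=N\c1ccnc2cc(Cl)ccc12)C(C)C`: 0.917 h
- compound 2 `C/C(=N/c1ccnc2cc(Cl)ccc12)NCCCCN1CCCCC1`: > 1 h
- compound 3 `C/C(=N/c1ccnc2cc(Cl)ccc12)NC1CCN(C)CC1`: > 1 h

All three were run in an ADME assay (liver) for metabolic stability, with Liver microsome (Homo sapiens) as the target, read by LC-MS, using microsomes, tested at 1 uM; a higher number here means that the compound lasts longer, a lower number that the compound disappears faster. For compound 2 the value is a limit of the assay and not a number. For compound 3 the value is likewise a limit. Compound 1 is the only one of the three with a number, and in this assay compound 1 gives 0.917 h. (the limit of > 1 h in this assay, at which 2 of the 3 values shown sit). Among the measured compounds shown here, no two of the measured compounds differ in only one place, so no measured step is available; compound 1 and compound 2 can only be set side by side as two values.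

The next compound, compound 4 `CCN(CC)CCCCN/C(C)=N\c1ccnc2cc(Cl)ccc12`, has not been measured in this assay. It differs from compound 2 as follows: diethylamino in place of piperidin-1-yl on a saturated chain carbon, four bonds along the chain from an amine nitrogen.

For the measured compounds named here, with no measured step to lean on, the step expected in this assay is none beyond the scatter, in either direction. Compound 1 also carries the diethylamino group and in this assay compound 1 gives 0.917 h. The expected step of a number no higher from compound 2 to compound 4 (the limit leaves the size open) is therefore small. For compound 4 the estimated half-life in this assay is 1 h, expected to fall between 0.5 h and 2 h, with a fair chance that only a limit is reported.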

Compound 4, half-life: > 1 h
Compound 4 was reported as a limit; the forecaster's own chance of this, stated with the estimate: 50%; the middle value sits exactly at the limit.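

In this assay compound 4 is reported as a limit and not a number, as compound 2 is, so the step for diethylamino in place of piperidin-1-yl on a saturated chain carbon, four bonds along the chain from an amine nitrogen, cannot be read in size or direction. What the limit does show is that a half-life at the limit is retained with diethylamino on this chain when the carbon with a double bond to nitrogen carries methyl. Among the compounds shown here, the first readable comparison at that carbon, methyl in place of isopropyl, gives an at least 1.0-fold higher number from compound 1 to compound 4 (0.03 log units; that floor lies within the scatter) and so supports no claim of a real change, while the limit leaves the upper size of the step open.

Going by these compounds, whether a morpholin-4-yl group in place of diethylamino, or a longer chain, would give a number and not a limit in this assay stays open. Values at the limit give no order among the compounds that sit there, and the series is still read mostly through that limit: the limit of > 1 h in this assay, at which 3 of the 4 values shown sit.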